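Methoxy count on the aryl-pyrazole end and cytotoxicity

The compounds below may be only part of what the source reports. "The series", "measured", "known", "first", "only" and "open" are said of these compounds alone.

The series shares one core: compound 1 `COc1ccc(-c2cc(/C=C/C(=O)c3ccc(N)cc3)[nH]n2)cc1` carries a single methoxy on the aryl ring attached to the pyrazole, compound 2 `COc1cc(-c2cc(/C=C/C(=O)c3ccc(N)cc3)[nH]n2)cc(OC)c1OC` carries three, and compound 3 `COc1cc(-c2cc(/C=C/C(=O)c3ccc(Cl)c(Cl)c3)[nH]n2)cc(OC)c1OC` keeps the three methoxy groups but swaps the aminophenyl ketone end for a dichlorophenyl one. In a functional assay on KM12 cells (Homo sapiens) for cytotoxicity, read by sulforhodamine B assay, with a stated time of 48 h, tested at 1 uM (on this read-out higher numbers stand for a weaker effect at the one concentration tested and lower numbers for a stronger effect), compound 2 gives 57%, the lowest of the three numbers; compound 1 gives 77% and compound 3 gives 85%, both beyond the scatter from compound 2.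

Compound 4 `COc1ccc(-c2cc(/C=C/C(=O)c3ccc(N)cc3)[nH]n2)cc1OC` differs from compound 2 by hydrogen in place of methoxy on an aromatic carbon. Within the data shown here, the only measured step, a number 28 percentage points higher from compound 2 to compound 3 (beyond the scatter), alters the ketone end of the molecule and so does not speak to the aryl-pyrazole end. Compounds 1 and 2 differ at this end but in two places at once, so the value of compound 1, 77%, and the value of compound 2, 57%, only bracket where a two-methoxy analogue might fall. Compound 4 is therefore expected to lie between them, with a step of a number 10 percentage points higher from compound 2 to compound 4 (within the scatter) estimated, giving an expected value of 67% within 50% to 85%.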

Compound 4, a percentage reported as activity, at one concentration (the size of the read-out at that concentration, not a potency): 88%
Estimate against measurement, compound 4: 21 percentage points below; the whole stated range lies below it.
By their numbers in this assay, from the lowest: compound 2; then compounds 1, 3 and 4 (each within the scatter of the next, the first and the last beyond it).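

At this position the methoxy matters: in this assay, hydrogen in place of methoxy, on the aromatic carbon ortho to a methoxy group, gives a number 31 percentage points higher from compound 2 to compound 4 (beyond the scatter), so the stronger effect of compound 2 is lost with this one group. Methoxy in place of hydrogen on the ring of compound 1 gives a number 11 percentage points higher from compound 1 to compound 4 (beyond the scatter), so adding a methoxy does not by itself strengthen the effect, and across compounds 1, 4 and 2 the read-out does not fall steadily as methoxy groups are added. Nothing available explains this reversal.

Still open, going by these compounds, is whether the effect of compound 2 needs a methoxy at this carbon, or whether a hydroxy group, an ethoxy group or a fluorine would serve as well. On these data alone, the same change on the dichlorophenyl ketone of compound 3 also remains open.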